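The compounds below may be only part of what the source reports. "The series", "measured", "known", "first", "only" and "open" are said of these compounds alone.

Working notes on the series. Three compounds have numbers in an assay on cell membranes for displacement of a labelled ligand from Neuronal acetylcholine receptor; alpha4/beta2 (Rattus norvegicus); a higher number here means a weaker inhibitor, a lower number a stronger inhibitor. Compound 1 `COc1ccc(Nc2ccc(N3CC4CC(C3)N4)nn2)cc1` gives 578 nM in this assay. Compound 2 `Clc1ccc(Nc2cncc(N3CC4CC(C3)N4)c2)cc1` gives 0.118 nM. Compound 3 `Clc1cccc(Nc2ccc(N3CC4CC(C3)N4)cn2)c1` gives 2.2 nM, the second highest of the three numbers; its nearest neighbour is compound 2, a lower number beyond the scatter, and its furthest is compound 1, a higher number beyond the scatter. Among the measured compounds shown here, no pair of the three measured compounds differs in a single place, so no single-point step among them is available.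

Compound 4 `Clc1ccc(Nc2ccc(N3CC4CC(C3)N4)cn2)cc1` has not yet been measured. It differs from compound 3 as counted here: 4-chlorophenyl in place of 3-chlorophenyl on a nitrogen on an aromatic ring The two have the same atoms joined differently, 4-chlorophenyl in place of 3-chlorophenyl on a nitrogen on an aromatic ring. Compound 2 carries 4-chlorophenyl on a different core and does not isolate this change. The expected step in this assay is small, toward a lower number, and may lie within the scatter: a 1.8-fold lower number from compound 3 to compound 4 (0.26 log units; within the scatter). Compound 4 is estimated at 1.2 nM, with a range from 0.3 nM to 5 nM.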

Compound 4, inhibition constant: 2.49 nM
Compound 4: middle estimate off by 2.1-fold (0.32 log units), on the low side; the range from low to high includes it.
By their numbers in this assay, from the lowest: compound 2; then compounds 3 and 4 (each within the scatter of the next); then compound 1.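

Among the compounds shown here, this is the first single-place step: in this assay, 4-chlorophenyl in place of 3-chlorophenyl on a nitrogen on an aromatic ring gives a 1.1-fold higher number from compound 3 to compound 4 (0.05 log units; within the scatter). On this core, the two chlorophenyl isomers therefore cannot be told apart in this read-out, so the placement of the chlorine on the ring carries no measurable weight between these two compounds. Nothing available bears on why the two isomers read alike.

The compounds shown leave open whether the same exchange would be equally silent on the core of compound 2, where only 4-chlorophenyl appears. They also leave open whether a phenyl ring carrying a nitrile or a carboxylic acid in place of the chlorine, on this same nitrogen, would stay in this range.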